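Working notes: carboxyphenoxy replacement on the biaryl position

The compounds below may be only part of what the source reports. "The series", "measured", "known", "first", "only" and "open" are said of these compounds alone.

Compound 1 `COc1cccc(-c2ccc([C@H]3S[C@@H](C)C(=O)Nc4c3c(C)nn4-c3ccccc3C)cc2)c1` carries a 3-methoxyphenyl group at the aromatic carbon para to the large group, and in an assay on isolated protein for agonist activity at Bile acid receptor (Homo sapiens), read by AlphaScreen, with a stated time of 30 min (a higher number here means that more compound is needed for the effect, a lower number that less compound is needed), compound 1 gives 1800 nM. Going by the values given here, it is the only member of the set with a reported number. Compound 2 `COC(=O)c1cccc(-c2ccc([C@H]3S[C@@H](C)C(=O)Nc4c3c(C)nn4-c3ccccc3C)cc2)c1`, which carries a methyl ester on the same ring, is reported in this assay as "not active" (no number reported). Compound 3 `Cc1ccccc1-n1nc(C)c2c1NC(=O)[C@H](C)S[C@@H]2c1ccc(OCc2ccccc2)cc1`, with a benzyloxy group in that position, is reported in this assay as "not active" (no number reported). Among the compounds with values here, no step between two numbered compounds is therefore available, and the scatter of the measurement is the only reference for judging change.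

Compound 4 `Cc1ccccc1-n1nc(C)c2c1NC(=O)[C@H](C)S[C@@H]2c1ccc(Oc2ccccc2C(=O)O)cc1` differs from compound 1 in a single place: 2-carboxyphenoxy in place of 3-methoxyphenyl on an aromatic carbon. An aryl ether with a free carboxylic acid replaces the biaryl linkage of compound 1. Two neighbours of compound 1 with altered groups in this position returned no number, and compound 2 shows that an ester on the ring is not tolerated, so the outcome is uncertain. The step from compound 1 to compound 4 is expected to be a 2.8-fold higher number from compound 1 to compound 4 (0.44 log units; beyond the scatter), that is, a loss beyond the scatter rather than a gain. For compound 4 the expected value in this assay is 5000 nM, within a range from 1200 nM to 20000 nM.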

Compound 4, half-maximal effective concentration: "not active" (no number reported)
Nothing numeric was reported for compound 4, and the estimate cannot be compared.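

No step can be read from compound 1 to compound 4, since compound 4 is reported as "not active" in this assay and gives no number. No measurement shown here bears on the cause of this result. The compounds shown leave open which groups at this position, other than 3-methoxyphenyl, give a measurable value.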